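The source may report more compounds than this note shows. Statements on the series, on what has been measured and on what is new or still open speak of the compounds shown alone.

Of the compounds shown here, three of the shared core have been measured in a functional assay on MOLT-4 cells (Homo sapiens) for cytotoxicity, with a stated time of 72 h; a higher number here means a weaker inhibitor, a lower number a stronger inhibitor. Compound 1 `COc1cc(/C=C2\CCC/C(=C\c3ccccc3[N+](=O)[O-])C2=O)cc(OC)c1OC` gives 702 nM, compound 2 `O=C1/C(=C/c2ccccc2)CCC/C1=C\c1cccc([N+](=O)[O-])c1` gives 1700 nM, and compound 3 `Cc1ccc(/C=C2\CCC/C(=C\c3ccc([N+](=O)[O-])cc3)C2=O)cc1` gives 8440 nM, the highest of the three numbers; compound 2 lies nearest to it and compound 1 furthest, and both gaps fall beyond the scatter. Compound 4 `O=C1/C(=C/c2ccc(Cl)cc2)CCC/C1=C\c1ccc([N+](=O)[O-])cc1` differs from compound 3 in one place: chloro in place of methyl on an aromatic carbon. For the measured compounds named here, no measured pair shows this change, so the expectation rests on compound 3 alone. A step of modest size is expected, more likely toward a lower number than a higher one, though it may well stay within the scatter, so the estimated step is a 1.7-fold lower number from compound 3 to compound 4 (0.23 log units; within the scatter). Compound 4 is therefore estimated at 5000 nM, within a range of 1500 nM to 16000 nM.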

Compound 4, half-maximal inhibitory concentration: 9120 nM
Beside the measured number, compound 4's estimate is 1.8-fold (0.26 log units) below it; low and high end bracket the measured number.
By their numbers in this assay, from the lowest: compound 1; then compound 2; then compounds 3 and 4 (each within the scatter of the next).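

Chloro in place of methyl on an aromatic carbon, para to a large group, gives a 1.1-fold higher number from compound 3 to compound 4 (0.03 log units; within the scatter) in this assay. This is the first comparison among these compounds that differs in one place, and it shows that 4-methylphenyl and 4-chlorophenyl cannot be told apart at this position in this assay. Nothing measured here offers a reason for this result.

As far as these compounds go, whether an amine or a carboxylic acid at this position would also leave the number within the scatter remains open. So does whether the same exchange would read alike with the other aryl group of the shared core changed.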